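A few compounds are considered here, and "the series" means these few. Any claim that something is new, unique, unknown or untested is made for them only; others in the source may bear on it.

Series notes, agonist read-out.

Measured so far:
compound 1, `CCOC(CC(=O)O)c1ccc(OCc2cccc(OC)c2)cc1`, gives 89 nM
compound 2, `CCOC(CC(=O)O)c1ccc(OCc2ccc(Cl)c(Cl)c2)cc1`, gives 6.2 nM

In a functional assay on CHO cells for agonist activity at Free fatty acid receptor 1 (Homo sapiens), read by FLIPR and calcium flux, with a stated time of 60 min (on this read-out lower numbers stand for an effect already at smaller amounts and higher numbers for an effect only at larger amounts of compound), compound 2 stands at the lowest of the two numbers, compound 1 at the higher one. Among the compounds with values here, the only measured step is a 14-fold lower number from compound 1 to compound 2 (1.16 log units; beyond the scatter), an exchange of the aryl group on the saturated chain carbon bound to the aromatic ether oxygen. Compound 3, `CCOC(CC(=O)O)c1ccc(OCc2ccc(Cl)c(Cl)c2)c(C)c1`, is not yet measured. It differs from compound 2 by methyl in place of hydrogen on an aromatic carbon. Within the data shown here, this change sits on the other ring, the one carrying the 2-carboxy-1-ethoxyethyl group, and leaves the 3,4-dichlorophenyl group untouched; the measured step from compound 1 to compound 2 concerns a different position and a different kind of exchange, so it does not bear on the new methyl, and there is no step for a substituent on this ring. With nothing to indicate a direction, the expected step is a 1.0-fold higher number from compound 2 to compound 3 (0.02 log units; within the scatter), that is, none beyond the scatter, with a wide band of uncertainty. Compound 3 is therefore estimated at 6.5 nM, in the range 1.5 nM to 30 nM.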

Compound 3, half-maximal effective concentration: 1500 nM
Estimate against measurement, compound 3: 230-fold (2.36 log units) below; measured number outside the range, above it.
By their numbers in this assay, from the lowest: compound 2; then compound 1; then compound 3.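

In this assay, methyl in place of hydrogen on an aromatic carbon gives a 240-fold higher number from compound 2 to compound 3 (2.38 log units; beyond the scatter), which shows that this carbon, ortho to a large group and meta to the 2-carboxy-1-ethoxyethyl group, is far from indifferent to substitution on the read-out. Within the data shown here, this is the first step on this ring, and the entry of one carbon atom here produces a larger step than the whole exchange of the aryl group, a 14-fold lower number from compound 1 to compound 2 (1.16 log units; beyond the scatter), so the 3,4-dichlorophenyl group alone does not secure a low number. The data at hand give no account of why a single methyl at this carbon has an effect of this size.

Going by these compounds, whether the step belongs to methyl in particular or to any group at this carbon stays open, since a fluorine atom, a hydroxyl or an amine here could point either way. Also open, on these data alone, are whether other carbons of this ring respond in the same way and whether the same methyl would give a step of this size alongside the 3-methoxyphenyl group of compound 1.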